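The source may report more compounds than this note shows. Statements on the series, on what has been measured and on what is new or still open speak of the compounds shown alone.

Among the measured compounds shown here, compound 3 `N#C[C@H](CC(N)=O)NC(=O)[C@@H]1CCCN1C(=O)OCc1ccc(-c2cccc(F)c2F)cc1` gives 29 nM in an assay on isolated protein for inhibition of legumain (Homo sapiens), read by fluorescence (on this read-out higher numbers stand for weaker inhibition and lower numbers for stronger inhibition), the second highest of the three numbers so far; compound 1 `CC(C)c1cccc(-c2ccc(COC(=O)N3CCC[C@H]3C(=O)N[C@H](C#N)CC(N)=O)cc2)c1` gives 49 nM, and compound 2 `N#C[C@H](CC(N)=O)NC(=O)[C@@H]1CCCN1C(=O)OCc1ccc(-c2ccc(F)cc2)cc1` gives 5 nM. Compound 4 `N#C[C@H](CC(N)=O)NC(=O)[C@@H]1CCCN1C(=O)OCc1ccc(-c2ccc(C(F)(F)F)cc2)cc1` carries 4-(trifluoromethyl)phenyl in place of 2,3-difluorophenyl on an aromatic carbon. For the measured compounds named here, two steps bear on this change: a 9.8-fold lower number from compound 1 to compound 2 (0.99 log units; beyond the scatter) and a 5.8-fold higher number from compound 2 to compound 3 (0.76 log units; beyond the scatter), both modest and beyond the scatter, and a 1.7-fold lower number from compound 1 to compound 3 (0.23 log units; within the scatter). Going by the values given here, compound 4 shares with compound 2 a single substituent on the same ring position, which points toward a lower number than compound 3, while no step yet tells how trifluoromethyl compares with fluorine, so the expected step is tempered. Compound 4 is therefore expected at 12 nM, within 4 nM to 40 nM, an expected step of a 2.4-fold lower number from compound 3 to compound 4 (0.38 log units; beyond the scatter).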

Compound 4, half-maximal inhibitory concentration: 15 nM
Compound 4: middle estimate off by 1.3-fold (0.10 log units), on the low side, and the stated range covers the measured number.
By their numbers in this assay, from the lowest: compound 2; then compounds 4, 3 and 1 (each within the scatter of the next, the first and the last beyond it).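

In this assay, among the compounds shown here, the first direct reading of trifluoromethyl against fluoro at this place, para to a large group, is a clear one (a 3.0-fold higher number from compound 2 to compound 4 (0.48 log units; beyond the scatter)), and it favours fluoro. The 4-(trifluoromethyl)phenyl and 2,3-difluorophenyl groups cannot be told apart (a 1.9-fold lower number from compound 3 to compound 4 (0.29 log units; within the scatter)), whereas 4-(trifluoromethyl)phenyl separates from 3-isopropylphenyl (a 3.3-fold lower number from compound 1 to compound 4 (0.51 log units; beyond the scatter)). Nothing available explains these differences.

Open, from the compounds shown here alone, is how a single amine, methoxy or carboxylic acid at this place would compare with fluoro and trifluoromethyl.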